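The source may report more compounds than this note shows. Statements on the series, on what has been measured and on what is new or still open speak of the compounds shown alone.

Compound 1 `CCn1c(SCC(=O)c2ccccc2)nnc1-c1ccc(OC)cc1` was examined in a functional assay on the whole organism (strain albino) for inhibition, with Rattus norvegicus as the target, read by paw edema, with a stated time of 5 h, at a dose of 0.28 mmol/kg by the oral route (a higher number here means more inhibition at the dose given (going by the name of the read-out), a lower number less inhibition), where compound 1 gives 61%. Compound 2 `C=CCn1c(SCC(=O)c2ccccc2)nnc1-c1ccc(OC)cc1` differs from it by one change, (vinyl in place of methyl on a saturated chain carbon bound to an aromatic nitrogen), and in this assay compound 2 gives 61%, so that the step of no change at the digits printed from compound 1 to compound 2 (within the scatter) is flat. Compound 3 `CCn1c(SC/C(=N/O)c2ccccc2)nnc1-c1cc(OC)c(OC)c(OC)c1` is built on a different core; the difference between the two cores is not broken down here. In this assay compound 3 gives 74%, the highest number of the three measured, standing beyond the scatter above both compound 1 and compound 2.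

Compound 4 `C=CCn1c(SC/C(=N/O)c2ccccc2)nnc1-c1cc(OC)c(OC)c(OC)c1` has not yet been measured. It is related to compound 3 by vinyl in place of methyl on a saturated chain carbon bound to an aromatic nitrogen, which is the same change that separates compound 1 from compound 2, at the same place. Because the step of no change at the digits printed from compound 1 to compound 2 (within the scatter) showed no movement, the step from compound 3 to compound 4 is expected to be about no change at the digits printed from compound 3 to compound 4 (within the scatter). Compound 4 is therefore estimated to give roughly 74% in this assay, with a plausible range from 62% to 84%.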

Compound 4, a percentage reported as inhibition, in the whole organism at one dose (the size of the read-out at that dose, not a potency): 77%
Beside the measured number, compound 4's estimate is 3 percentage points below it; low and high end bracket the measured number.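

Carried to the core of compound 3, vinyl in place of methyl on a saturated chain carbon bound to an aromatic nitrogen gives, in this assay, a number 3 percentage points higher from compound 3 to compound 4 (within the scatter). Set beside the earlier step, the change reads alike on both cores: the same change on two cores in this assay, no change at the digits printed (within the scatter) from compound 1 to compound 2 and a number 3 percentage points higher (within the scatter) from compound 3 to compound 4, 3 percentage points apart, within the scatter of two such steps. This shows that, on these two cores, ethyl and allyl at this place cannot be told apart by this read-out at this single dose and time, but it does not show that the change would stay flat on a third core or under other conditions, and two pairs are too few to establish a rule for the series.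

The compounds shown leave open what a longer chain such as butyl, a benzyl group or a chain carrying an amine would do at this place. Among the compounds shown here, they also leave open which of the differences between the two cores matters for this read-out, as no pair here separates them.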